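A few compounds are considered here, and "the series" means these few. Any claim that something is new, unique, unknown or untested is made for them only; others in the source may bear on it.

Three ureas have been measured so far in an assay for inhibition of C-X-C chemokine receptor type 1 (Homo sapiens), read by radioligand binding; on this read-out lower numbers stand for stronger inhibition and higher numbers for weaker inhibition. Compound 1 `O=C(Nc1ccccc1)Nc1ccc([N+](=O)[O-])cc1O` carries a nitro group and gives 18200 nM. Compound 3 `N#Cc1ccc(NC(=O)Nc2ccccc2)c(O)c1` carries a cyano group on the same core and gives 21000 nM; the step of a 1.2-fold higher number from compound 1 to compound 3 (0.06 log units; within the scatter) shows that swapping these two groups changes little. Compound 2 `N#Cc1ccc(NC(=O)Nc2ccccc2Br)c(O)c1Cl`, which carries both a bromo and a chloro group in addition to the cyano group, gives 4200 nM. Among the three numbers, compound 3 stands highest, close to compound 1 and furthest from compound 2.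

Compound 4 `N#Cc1ccc(NC(=O)Nc2ccccc2Br)c(O)c1` is not yet measured. It differs from compound 3 by bromo in place of hydrogen on an aromatic carbon. Within the data shown here, no measured pair shows this exact change on its own. Among the measured compounds shown here, the only pair that touches it is compound 3 against compound 2, but those two structures differ in two places, the bromo group and a chloro group, so their values show only the combined effect of both. Part of that combined shift may belong to the bromo group, so a downward step, expected to be a 2.6-fold lower number from compound 3 to compound 4 (0.42 log units; beyond the scatter) in this assay, seems reasonable, though its size is uncertain. Compound 4 is therefore estimated at 8000 nM, with a likely range from 3000 nM to 21000 nM.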

Compound 4, half-maximal inhibitory concentration: 15100 nM
Compound 4: the middle estimate sits 1.9-fold (0.28 log units) below what was measured; measured number inside the range.
By their numbers in this assay, from the lowest: compound 2; then compounds 4, 1 and 3 (each within the scatter of the next).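

In this assay, bromo in place of hydrogen on an aromatic carbon, ortho to a large group, gives a 1.4-fold lower number from compound 3 to compound 4 (0.14 log units; within the scatter) and so, taken alone, does not separate the two compounds. Hydrogen in place of chloro on an aromatic carbon, with the bromo group kept, gives a 3.6-fold higher number from compound 2 to compound 4 (0.56 log units; beyond the scatter) and is the first single change in this set to reach beyond the scatter, which ties the lower number of compound 2 to its chloro group, at least when the bromo group is also there. No measurement is at hand that explains either step.

Among the compounds shown, none carries the chloro group without the bromo group, so it stays open whether the chloro group would give a similar step alone or only works together with the bromo group. Going by these compounds, it is also open how a fluoro, methyl or methoxy group would behave in place of the bromo group, or an amine or a carboxylic acid in place of the chloro group.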